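The source may hold more compounds than are shown below. What is called first, only, known or untested is meant among the compounds shown, and "the series" means these compounds.

Measured so far in a functional assay on LNCaP cells (Homo sapiens) for cytotoxicity; on this read-out higher numbers stand for weaker inhibition and lower numbers for stronger inhibition

compound 1 `CNC(=O)Nc1ccc(-c2nc(N3CC4CCC(C3)O4)c3cnn(C)c3n2)cc1` gives 170 nM
compound 2 `CNC(=O)Nc1ccc(-c2nc(N3CC4CCC(C3)O4)c3cnn(C4CCC5(CC4)OCCCO5)c3n2)cc1` gives 8 nM
compound 3 `CNC(=O)Nc1ccc(-c2nc(N3CC4CCC(C3)O4)c3cnn([C@H]4CC[C@H](OC)CC4)c3n2)cc1` gives 2 nM

Compound 3 holds the lowest number of the three, and its gaps to both others lie beyond the scatter. Compound 4 `CNC(=O)Nc1ccc(-c2nc(N3CC4CCC(C3)O4)c3cnn([C@H]4CC[C@H](O)CC4)c3n2)cc1` is unmeasured and differs from compound 3 by hydrogen in place of methyl on an oxygen on a saturated carbon, or methoxy to hydroxy.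

Within the data shown here, no measured step isolates this change. The nearest evidence concerns the group on the aromatic nitrogen. Two large steps point downward, an 85-fold lower number from compound 1 to compound 3 (1.93 log units; beyond the scatter) and a 21-fold lower number from compound 1 to compound 2 (1.33 log units; beyond the scatter), while exchanging the two larger groups gave only a modest step, a 4.0-fold lower number from compound 2 to compound 3 (0.60 log units; beyond the scatter), in this series. Compound 4 keeps the 4-substituted cyclohexyl ring, so most of the gain over compound 1 is expected to remain, with a modest rise in the number. The expected step is a 2.0-fold higher number from compound 3 to compound 4 (0.30 log units; within the scatter) in this estimate. For compound 4 the estimated value is 4 nM, with an expected range from 1.5 nM to 12 nM.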

Compound 4, half-maximal inhibitory concentration: 20 nM
Beside the measured number, compound 4's estimate is 5.0-fold (0.70 log units) below it, outside the stated range (above it).
By their numbers in this assay, from the lowest: compound 3; then compound 2; then compound 4; then compound 1.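

In this assay, among these compounds, the methyl on the oxygen carries weight of its own: going from methoxy to hydroxy gives a 10-fold higher number from compound 3 to compound 4 (1.00 log units; beyond the scatter), a change that the earlier steps, all made on the group as a whole, could not separate. On the aromatic nitrogen, 4-hydroxycyclohexyl keeps only part of the gain over methyl, with an 8.5-fold lower number from compound 1 to compound 4 (0.93 log units; beyond the scatter), and it also loses ground to the larger group bearing two oxygens, with a 2.5-fold higher number from compound 2 to compound 4 (0.40 log units; beyond the scatter), so the 4-substituted cyclohexyl ring alone does not secure the lowest numbers in the series. Nothing measured here explains the methoxy to hydroxy step.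

Going by these compounds, how an ethoxy group or an amine on the same saturated ring carbon would read in this assay remains open. Also open, on these data alone, is whether a longer chain on the oxygen would hold or lower the number reached with methyl.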